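This account rests on a few compounds, and the source may have more. Where it says the series, first, only, none or still open, it means among the compounds named here.

Measured compounds:
- compound 1 `Cc1ccc(S(=O)(=O)c2cnc3ccc(Cl)cc3c2N2CCC(C)CC2)cc1C`: 84%
- compound 2 `Cc1ccc(S(=O)(=O)c2cnc3ccc(F)cc3c2N2CCC(C)CC2)cc1C`: 92%
- compound 3 `COc1ccc2ncc(S(=O)(=O)c3cc(C)cc(C)c3)c(N3CCC(C)CC3)c2c1`: 79%

In an assay on isolated protein for displacement of a labelled ligand from metabotropic glutamate receptor 5 (Homo sapiens), with a stated time of 60 min, tested at 1 uM (on this read-out lower numbers stand for less inhibition and higher numbers for more inhibition at the one concentration tested (going by the name of the read-out)), compound 1 gives 84%, the second highest of the three numbers shown. Its nearest neighbour is compound 3 with 79%, a gap within the scatter; the furthest is compound 2, where the change a number 8 percentage points higher from compound 1 to compound 2 (within the scatter) also stays within the scatter. All three compounds thus sit at a similar, high level of inhibition.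

Compound 4 `COc1cccc(S(=O)(=O)c2cnc3ccc(Cl)cc3c2N2CCC(C)CC2)c1` differs from compound 1 in one place: 3-methoxyphenyl in place of 3,4-dimethylphenyl on a sulfonyl sulfur. Within the data shown here, no measured step touches this part of the molecule. Among the measured compounds shown here, the only measured step, from compound 1 to compound 2, concerns the halogen on the core, and compound 3 differs from compound 1 in more than one place, so its value alone cannot isolate the group on the sulfonyl sulfur. Without a comparable step, the expectation for compound 4 rests on the narrow spread of the three measured values, and a change no larger than the scatter seems most likely. Compound 4 is therefore estimated at 76%, with a range from 55% to 92%. This estimate corresponds to an expected step of a number 8 percentage points lower from compound 1 to compound 4 (within the scatter).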

Compound 4, a percentage reported as inhibition, at one concentration (the size of the read-out at that concentration, not a potency): 87%
Compound 4: middle estimate off by 11 percentage points, on the low side, within the range that was stated.
By their numbers in this assay, from the lowest: compounds 3, 1, 4 and 2 (each within the scatter of the next, the first and the last beyond it).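

In this assay, putting 3-methoxyphenyl in place of 3,4-dimethylphenyl on a sulfonyl sulfur gives a number 3 percentage points higher from compound 1 to compound 4 (within the scatter). Among these compounds, this is the first direct look at this position, and it shows that this exchange leaves the read-out indistinguishable from that of compound 1, even though the entering group carries a hydrogen-bond acceptor and the leaving group carries none. No measurement here explains why the two groups give such similar numbers.

As far as these compounds go, it remains open whether this position would accept a more different group, such as a carboxylic acid or an amine on the phenyl ring, or a plain methyl in place of the ring. From the compounds shown here alone, each reading comes from one concentration, so the compounds' potencies also remain unknown.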